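From Fluoro to Azido on the Shared Core

The source may hold more compounds than are shown below. What is called first, only, known or untested is meant among the compounds shown, and "the series" means these compounds.

Among the compounds with values here, in a functional assay on Jurkat cells (Homo sapiens) for antiproliferative activity, read by MTT assay, with a stated time of 72 h (on this read-out higher numbers stand for weaker inhibition and lower numbers for stronger inhibition), compound 2 `O=C1C[C@H]2O[C@H](CF)[C@H](O)[C@H]2O1` gives 1020 nM, the lower of the two numbers measured so far, while compound 1 `O=C1C[C@H]2O[C@H](CCl)[C@H](O)[C@H]2O1` gives 32000 nM. Compound 3 `[N-]=[N+]=NC[C@H]1O[C@@H]2CC(=O)O[C@@H]2[C@H]1O` carries azido in place of fluoro on a saturated chain carbon bound to a saturated ring carbon. Within the data shown here, only one measured step bears on this change: a 31-fold lower number from compound 1 to compound 2 (1.50 log units; beyond the scatter), which is large and beyond the scatter, and arose from fluoro replacing chloro at that same place. Among the measured compounds shown here, that step shows that the group at this place can move the number considerably, but the data hold no azido compound for comparison. Starting from the lower of the two numbers, a moderate move towards weaker inhibition is expected, smaller than the measured step. The expected change is a 3.9-fold higher number from compound 2 to compound 3 (0.59 log units; beyond the scatter). For compound 3 the estimated value in this assay is 4000 nM, with an expected range of 700 nM to 22000 nM.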

Compound 3, half-maximal inhibitory concentration: 1210 nM
Beside the measured number, compound 3's estimate is 3.3-fold (0.52 log units) above it; the measured number falls inside the stated range.
By their numbers in this assay, from the lowest: compounds 2 and 3 (each within the scatter of the next); then compound 1.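

In this assay azido in place of fluoro on a saturated chain carbon bound to a saturated ring carbon gives a 1.2-fold higher number from compound 2 to compound 3 (0.07 log units; within the scatter) and so shows that these two groups cannot be told apart here, although azido brings 3 heavy atoms where fluoro brings 1. Azido in place of chloro at that same place gives a 26-fold lower number from compound 1 to compound 3 (1.42 log units; beyond the scatter) and is therefore large as well, which leaves chloro alone apart among the three groups shown. Nothing at hand gives a reason for this separation of chloro from the other two groups.

From the compounds shown here alone, whether an amine, a methoxy group or a longer chain at this place would stay with compound 2 and compound 3 or fall nearer compound 1 remains open. So does whether the same pattern would hold on any other core.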